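A Methyl Next to the Ring Nitrogen

A few compounds are considered here, and "the series" means these few. Any claim that something is new, unique, unknown or untested is made for them only; others in the source may bear on it.

Three compounds sharing a core were compared in a functional assay on SF-295 cells (Homo sapiens) for antiproliferative activity; on this read-out higher numbers stand for weaker inhibition of growth and lower numbers for stronger inhibition of growth. Compound 1 `Cc1ccc2c(O)cc(-c3cccc(Cl)c3)nc2n1` gives 22.9 nM. Compound 3 `Cc1cc(C)c2c(O)cc(-c3cccc(Cl)c3)nc2n1` gives 47.9 nM; the change methyl in place of hydrogen on an aromatic carbon produced a 2.1-fold higher number from compound 1 to compound 3 (0.32 log units; beyond the scatter). Compound 2 `Oc1cc(-c2ccc3ccccc3c2)nc2ncccc12` gives 9120 nM, the highest number of the three; how its core differs from that of compound 1 is not broken down here. Compound 4 `Cc1ccc2c(O)cc(-c3ccc4ccccc4c3)nc2n1` is not yet measured and arises from compound 2 through (methyl in place of hydrogen on an aromatic carbon). This is the same kind of change as that from compound 1 to compound 3, but not the same: here the methyl is next to the ring nitrogen and para to a fused ring, whereas before it was ortho to a fused ring, meta to a methyl group and opposite the ring nitrogen. Resting on the measured 2.1-fold higher number from compound 1 to compound 3 (0.32 log units; beyond the scatter), the expected step is a 1.8-fold lower number from compound 2 to compound 4 (0.26 log units; within the scatter). Compound 4 is estimated at 5000 nM, from 1500 nM to 20000 nM.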

Compound 4, concentration for 50% growth inhibition: 3800 nM
For compound 4 the middle estimate is 1.3-fold (0.12 log units) above the measured one; measured number inside the range.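

The new step is a 2.4-fold lower number from compound 2 to compound 4 (0.38 log units; beyond the scatter), so adding a methyl lowered the number here, whereas the earlier addition raised it. The same kind of change therefore does not carry over as a fixed shift between these cores: the same change on two cores in this assay, a 2.1-fold higher number (0.32 log units; beyond the scatter) from compound 1 to compound 3 and a 2.4-fold lower number (0.38 log units; beyond the scatter) from compound 2 to compound 4, 5.0-fold (0.70 log units) apart, beyond the scatter of two such steps. This does not show whether the core or the position of the methyl sets the direction, as the two steps differ in both and two pairs are too few to separate them.

On these data alone, it remains open how an ethyl, a methoxy or an amine would behave next to the ring nitrogen in place of the methyl. As far as these compounds go, the effect of a second methyl on compound 4 also remains open, and that step would match the change from compound 1 to compound 3 more closely.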